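Moving the Aryl Group from Chloro to Methoxy

The source may hold more compounds than are shown below. What is called first, only, known or untested is meant among the compounds shown, and "the series" means these compounds.

In a functional assay on HL-60 cells (Homo sapiens) for inhibition, read by MTT assay, with a stated time of 72 h (a higher number here means a weaker inhibitor, a lower number a stronger inhibitor), compound 3 (`Cc1nc(-c2ccccc2Cl)c(C(=O)N2CCN(c3cccc(Cl)c3)CC2)o1`) gives 132 nM, the higher of the two numbers reported so far. Compound 2 (`Cc1nc(-c2cccc(F)c2)c(C(=O)N2CCN(c3cccc(Cl)c3)CC2)o1`) gives 33.7 nM, and compound 1 (`COc1ccc(-c2nc(C)oc2C(=O)N2CCN(c3cccc(Cl)c3)CC2)cc1OC`) is recorded as "not active" (no number reported), with no number. Compound 4 (`COc1ccc(-c2nc(C)oc2C(=O)N2CCN(c3cccc(Cl)c3)CC2)cc1`) carries 4-methoxyphenyl in place of 2-chlorophenyl on an aromatic carbon of a five-membered aromatic ring with 1 nitrogen and 1 oxygen (4-methoxyphenyl in place of 2-chlorophenyl on an aromatic carbon).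

Among the measured compounds shown here, no measured step covers this exchange directly. The closest guide is a 3.9-fold higher number from compound 2 to compound 3 (0.59 log units; beyond the scatter), which shows that a change of aryl group at this place can move the number by a modest amount. Compound 1, which also has a methoxy-bearing phenyl there, is recorded as "not active" (no number reported), so the expectation leans towards a weaker result, and a report without a number remains possible. The expected change is therefore a modest rise, a 2.3-fold higher number from compound 3 to compound 4 (0.36 log units; beyond the scatter). Compound 4 is expected at about 300 nM, with an estimated range of 40 nM to 2000 nM.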

Compound 4, half-maximal inhibitory concentration: "not active" (no number reported)
Nothing numeric was reported for compound 4; no gap can be computed for the estimate.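

Among the compounds shown here, with compound 4 recorded in this assay as "not active" (no number reported) without a number, no step from compound 3 to compound 4 can be read. Nothing shown accounts for this result. The compounds shown leave open how far 4-methoxyphenyl at this place stands from 2-chlorophenyl.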